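The source may report more compounds than this note shows. Statements on the series, on what has been measured and on what is new or still open speak of the compounds shown alone.

In an assay on membranes from HEK293 cells for displacement of a labelled ligand from Translocator protein (Homo sapiens), read by scintillation counting, with a stated time of 90 min (a lower number here means a stronger inhibitor, a higher number a weaker inhibitor), compound 1 `CCN(CC)C(=O)c1cc2cc(C)ccc2n1Cc1ccc(OCc2ccccc2)cc1` gives > 10000 nM, which is a limit of the assay and not a number. Compound 2 `CCN(CC)C(=O)c1cc2cc(C)ccc2n1Cc1ccc(O)cc1` likewise gives > 10000 nM in this assay, again a limit. The step that the two limits leave unreadable from compound 1 to compound 2 cannot be read; the two values only show that neither compound reaches a measurable number. Among the compounds with values here, compound 3 `COc1ccc(CN(C(C)=O)c2cc(C)cc(C)c2)cc1` stands apart as the single numbered value of the set, giving 500 nM in this assay, while the other two entries sit at the limit of > 10000 nM in this assay, at which 2 of the 3 values shown sit. Compound 4 `CC(=O)N(Cc1ccc(OC(C)C)cc1)c1cc(C)cc(C)c1` is not yet measured; it differs from compound 3 by isopropyl in place of methyl on an oxygen on an aromatic ring. Within the data shown here, no measured step bears on this change: the only recorded step concerns a different alteration on a different core and lies between two limits, so its size is unknown. With nothing to point either way, the expected step of a 1.1-fold lower number from compound 3 to compound 4 (0.05 log units; within the scatter) in this assay is estimated to stay within the usual scatter, neither a clear gain nor a clear loss. For compound 4 the estimate in this assay is 450 nM, within 150 nM to 1500 nM.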

Compound 4, inhibition constant: 823 nM
For compound 4 the middle estimate is 1.8-fold (0.26 log units) below the measured one; the measured number falls inside the stated range.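

In this assay, methoxy to isopropoxy on the aromatic ring gives a 1.6-fold higher number from compound 3 to compound 4 (0.22 log units; within the scatter), so this position accepts the branched isopropyl group in place of methyl without a step that can be told from the scatter. Within the data shown here, this is the first readable step at an oxygen on an aromatic ring, as the earlier step on the core of compound 1 cannot be read. No measurement shown gives a cause for this step.

From the compounds shown here alone, how far this position stays open to larger groups remains unsettled: a longer chain such as butyl, or a chain ending in an amine or a carboxylic acid, could keep or lose binding. Going by these compounds, whether hydrogen or benzyl on this oxygen behaves on the core of compound 3 as the isopropyl group does also remains open.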